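The compounds below may be only part of what the source reports. "The series", "measured", "known", "first", "only" and "open" are said of these compounds alone.

In a physicochemical assay for lipophilicity, at pH 7.4 (a lower number here means a more polar compound, a higher number a more lipophilic compound), compound 2 `C[C@@H]1[C@@H]2CN(c3nc(Nc4cnn(CCO)c4)ncc3F)C[C@]12NC(=O)[C@@H]1C[C@H]1C#N` gives 1.71 as the lowest of three measured numbers, with compound 3 `C[C@@H]1[C@@H]2CN(c3nc(Nc4cnn(CCO)c4)ncc3F)C[C@]12NC(=O)C1CC1` at 2.1 and compound 1 `C[C@@H]1[C@@H]2CN(c3nc(Nc4cnn(C)c4)ncc3F)C[C@]12NC(=O)[C@H]1C[C@@H]1C#N` at 2.32 above it. Compound 4 `C[C@@H]1[C@@H]2CN(c3nc(Nc4cnn(C)c4)ncc3F)C[C@]12NC(=O)[C@@H]1C[C@H]1C#N` differs from compound 2 by hydrogen in place of hydroxymethyl on a saturated chain carbon bound to an aromatic nitrogen in one place: hydrogen in place of hydroxymethyl on a saturated chain carbon bound to an aromatic nitrogen. Going by the values given here, no measured step makes this exact change. Among the compounds with values here, the one measured step of a number 0.39 log units higher from compound 2 to compound 3 (beyond the scatter) is modest and puts hydrogen in place of cyano at a different place, so it guides size only. Compound 1 also carries 1-methyl-1H-pyrazol-4-yl and stands at 2.32 on the same scale. A rise beyond the scatter is therefore expected in this assay rather than a fall. The expected step is a number 0.54 log units higher from compound 2 to compound 4 (beyond the scatter) on this estimate. Compound 4 is estimated at 2.25 with a range from 1.95 to 2.55 overall.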

Compound 4, distribution coefficient: 2.35
The estimate for compound 4 lay 0.10 log units below the measured number; low and high end bracket the measured number.
By their numbers in this assay, from the lowest: compound 2; then compounds 3, 1 and 4 (each within the scatter of the next).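

In this assay, the swap of 2-hydroxyethyl for methyl now has a directly measured size: a number 0.64 log units higher from compound 2 to compound 4 (beyond the scatter). The second new step, a number 0.03 log units higher from compound 1 to compound 4 (within the scatter), puts no readable distance between two stereoisomers, so on this scale the drawn configuration does not separate this pair, and the comparison is a clean one: the fact that compounds 1 and 4 differ only in the configuration as drawn.

The compounds shown leave open whether the hydroxyl or the chain itself accounts for the first step, since an ethyl group at this place would separate the two. From the compounds shown here alone, how an amine or a carboxylic acid at the chain end would read on this scale also stays open.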